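Aryl ketone swap in the chalcone series: halogens revisited

The compounds below may be only part of what the source reports. "The series", "measured", "known", "first", "only" and "open" are said of these compounds alone.

Compound 2 `COc1ccc(C(=O)/C=C/c2cc(-c3cc(OC)c(OC)c(OC)c3)n[nH]2)cc1OC` gives 5980 nM in a functional assay on UACC-62 cells (Homo sapiens) for inhibition, read by sulforhodamine B assay, with a stated time of 48 h (a lower number here means that less compound is tolerated, a higher number that more compound is tolerated), and is the only one of the two measured compounds to return a number. Compound 1 `COc1cc(-c2cc(/C=C/C(=O)c3ccc(Cl)c(Cl)c3)[nH]n2)cc(OC)c1OC` sits at a limit of the assay with > 100000 nM. Among the measured compounds shown here, the single measured step, an at least 16-fold lower number from compound 1 to compound 2 (1.22 log units; beyond the scatter), links the dichloro and dimethoxy ketone arms, and its dichloro end is captured only as the limit of > 100000 nM in this assay, at which 1 of the 2 values shown sits. Compound 3 `COc1cc(-c2cc(/C=C/C(=O)c3ccc(F)c(F)c3)[nH]n2)cc(OC)c1OC` is the unmeasured member; relative to compound 2 it carries 3,4-difluorophenyl in place of 3,4-dimethoxyphenyl on a carbonyl carbon. For the measured compounds named here, the only measured step that bears on this change is an at least 16-fold lower number from compound 1 to compound 2 (1.22 log units; beyond the scatter), which runs from a dihalogenated ketone arm to the dimethoxy arm. The change to compound 3 runs back towards a dihalogenated arm, so a large step upward in this assay is expected, of roughly the size of an 8.4-fold higher number from compound 2 to compound 3 (0.92 log units; beyond the scatter), with a fair chance that the value again comes back only as a limit. Compound 3 is therefore expected to show 50000 nM in this assay, within 10000 nM to 250000 nM.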

Compound 3, concentration lethal to 50% of the cells: 35300 nM
Beside the measured number, compound 3's estimate is 1.4-fold (0.15 log units) above it; the measured number falls inside the stated range.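

In this assay, among the compounds shown here, the 3,4-difluorophenyl group on the carbonyl carbon gives the first real number for a dihalogenated ketone arm, and the swap from 3,4-dimethoxyphenyl is a 5.9-fold higher number from compound 2 to compound 3 (0.77 log units; beyond the scatter), so the direction first suggested by a limit now rests on a measured value. The two halogens are also separated at this position, with 3,4-difluorophenyl in place of 3,4-dichlorophenyl giving an at least 2.8-fold lower number from compound 1 to compound 3 (0.45 log units; beyond the scatter), which means that a dihalogenated arm does not by itself fix the result and that this step is bounded on one side only. Compound 1 remains a limit rather than a number, so the full distance between the two halogenated arms stays unknown: the limit of > 100000 nM in this assay, at which 1 of the 3 values shown sits.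

The compounds shown leave open whether the lower number with the 3,4-dimethoxyphenyl arm is specific to methoxy groups or would also appear with an amine or a carboxylic acid on that phenyl ring. They also leave open whether a single fluorine or a trifluoromethyl group on the ketone arm would follow the 3,4-difluorophenyl result in this assay.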